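The source may hold more compounds than are shown below. What is called first, only, known or untested is meant among the compounds shown, and "the series" means these compounds.

Measured in a functional assay on B16 cells (Mus musculus) for cytotoxicity, read by MTT assay, with a stated time of 48 h; on this read-out higher numbers stand for weaker inhibition and lower numbers for stronger inhibition:
compound 1 `O=C(NCc1cn(Cc2ccccc2)nn1)c1cn(Cc2ccccc2)nn1`: 300 nM
compound 2 `CC(=O)OCCn1cc(C(=O)NCc2cn(Cc3ccccc3)nn2)nn1`: > 100000 nM, a limit of the assay

For compound 2 there is no number, only a limit: the limit of > 100000 nM in this assay, at which 1 of the 2 values shown sits.

Compound 3 `CC(=O)OCCn1cc(CNC(=O)c2cn(CCOC(C)=O)nn2)nn1` differs from compound 2 by acetoxymethyl in place of phenyl on a saturated chain carbon bound to an aromatic nitrogen. In words, this is acetoxymethyl in place of phenyl on a saturated chain carbon bound to an aromatic nitrogen, or benzyl to 2-acetoxyethyl.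

Within the data shown here, one measured step bears on this, the same exchange made elsewhere in the molecule: an at least 330-fold higher number from compound 1 to compound 2 (2.52 log units; beyond the scatter). That step was large and beyond the scatter. On its strength, a change toward higher numbers is expected again in this assay. Going by these compounds, compound 2 gives no number to start from, so the size of the step stays open, and another limit is the likeliest report. The estimated step is a step that the limit leaves unreadable from compound 2 to compound 3. For compound 3 the estimated value is 150000 nM, with an expected range of 40000 nM to 500000 nM.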

Compound 3, half-maximal inhibitory concentration: > 100000 nM
Compound 3 was reported as a limit (the forecaster's own chance of this, stated with the estimate: 85%); the middle value is on the limit's open side.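

Compound 2 and compound 3 are both reported only as limits, so no step between them can be read: the limit of > 100000 nM in this assay, at which 2 of the 3 values shown sit.

Going by these compounds, what stays open is how far each compound lies past that limit, and whether benzyl to 2-acetoxyethyl from compound 2 to compound 3 changes the read-out at all.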